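Pyrazolylamino series: removing the two methyls from compound 2

This account rests on a few compounds, and the source may have more. Where it says the series, first, only, none or still open, it means among the compounds named here.

Three compounds have numbers in an assay on isolated protein for binding affinity to Leucine-rich repeat serine/threonine-protein kinase 2 variant G2019S (Homo sapiens), read by TR-FRET and LanthaScreen, with a stated time of 2 h; on this read-out lower numbers stand for stronger inhibition and higher numbers for weaker inhibition. Compound 1 `C[C@@H]1CCCN1c1c(C#N)c2c(N)nc(Nc3ccn(C)n3)cc2n1C` gives 13 nM in this assay. Compound 2 `Cc1nn(C)cc1Nc1nc(N)c2c(C#N)c(N3CCC[C@H]3C)n(C)c2n1` gives 2 nM in this assay, the lowest of the three numbers: compound 1 sits at a higher number beyond the scatter, and compound 3 `C[C@@H]1CCCN1c1[nH]c2ncnc(N)c2c1C#N`, which in this assay gives 14 nM, sits further still, also beyond the scatter. Compound 2 is therefore the strongest binder among the three as measured.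

Compound 4 `C[C@@H]1CCCN1c1c(C#N)c2c(N)nc(Nc3cn[nH]c3)nc2n1C` has not been measured in this assay. It differs from compound 2 in one place: 1H-pyrazol-4-yl in place of 1,3-dimethyl-1H-pyrazol-4-yl on a nitrogen on an aromatic ring. Both methyl groups of the 1,3-dimethyl-1H-pyrazol-4-yl are gone, the 1H-pyrazol-4-yl bringing one hydrogen-bond donor where the group it replaces had none.

Among the compounds with values here, no step between two measured compounds that differ in one place is available, so the size of this change can only be expected, not read from a neighbour. The shared core is kept intact, and the three measured compounds all sit at low numbers, so a large loss is not expected; a modest move toward a higher number, of a size near the edge of the scatter, is the working estimate for the step of a 3.0-fold higher number from compound 2 to compound 4 (0.48 log units; beyond the scatter).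

Compound 4 is thus estimated at 6 nM in this assay, with a range from 2 nM to 20 nM.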

Compound 4, inhibition constant: 0.4 nM
Estimate against measurement, compound 4: 15-fold (1.18 log units) above; the whole stated range lies above it.
By their numbers in this assay, from the lowest: compound 4; then compound 2; then compounds 1 and 3 (each within the scatter of the next).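

In this assay, within the data shown here, the change from 1,3-dimethyl-1H-pyrazol-4-yl to 1H-pyrazol-4-yl on this nitrogen gives a 5.0-fold lower number from compound 2 to compound 4 (0.70 log units; beyond the scatter), the first step that can be read between two compounds differing in one place. It shows that neither methyl of the 1,3-dimethyl-1H-pyrazol-4-yl is required for strong binding in this assay, and that the smaller group, with its one hydrogen-bond donor, binds better here rather than merely being tolerated. The data shown offer no measurement that accounts for this gain.

The loss of both methyls and the gain of the donor arrive together in this single step, so the compounds shown cannot separate the contribution of either methyl from that of the donor, and a pyrazol-4-yl keeping a single methyl would be needed to divide them. On these data alone, it also remains open whether this place accepts anything other than a pyrazole, such as a phenyl, or whether a larger group such as an ethyl on the pyrazole nitrogen reverses the step.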